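Lengthening an Ester Chain: What to Expect for Compound 4

The source may hold more compounds than are shown below. What is called first, only, known or untested is meant among the compounds shown, and "the series" means these compounds.

Compound 3 `COC(=O)c1c(NC(=S)Nc2cccc3ccccc23)sc2c1CCC2` has the lowest number of the three compounds measured in an assay on HEK-Blue hTLR2 cells for agonist activity at Toll-like receptor 2 (Homo sapiens), with a stated time of 24 h (a lower number here means that less compound is needed, a higher number that more compound is needed for the effect), giving 3570 nM. Compound 1 `COC(=O)c1c(NC(=S)Nc2ccc(C)cc2)sc2c1CCCC2` gives 10300 nM in this assay, and compound 2 `CCOC(=O)c1c(N=C(S)Nc2ccc(F)cc2)sc2c1CCC2` gives 13300 nM; both gaps to compound 3 lie beyond the usual scatter. Compound 4 `CCCOC(=O)c1c(NC(=S)Nc2cccc3ccccc23)sc2c1CCC2` differs from compound 3 in one place: ethyl in place of hydrogen on a saturated chain carbon bound to an oxygen next to a carbonyl group, so that a methoxycarbonyl becomes a propoxycarbonyl. Going by the values given here, no measured pair shows this change on its own, so its size has no direct guide. The step is expected to be small, at most modestly toward a lower number, and is estimated as a 1.2-fold lower number from compound 3 to compound 4 (0.08 log units; within the scatter). Compound 4 is therefore expected to give about 3000 nM in this assay, within a range from 1000 nM to 10000 nM.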

Compound 4, half-maximal effective concentration: 820 nM
The estimate for compound 4 lay 3.7-fold (0.56 log units) above the measured number, outside the stated range (below it).
By their numbers in this assay, from the lowest: compound 4; then compound 3; then compounds 1 and 2 (each within the scatter of the next).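

The ester chain is a place where a change counts: going from methoxycarbonyl to propoxycarbonyl gives a 4.4-fold lower number from compound 3 to compound 4 (0.64 log units; beyond the scatter) in this assay, the first single-place step seen in this series. Going by these compounds alone, it is also the only such step, so it describes one pair and not a general rule. No supporting measurement accounts for its size.

As far as these compounds go, whether a longer chain, such as butoxycarbonyl, or a carboxylic acid at this place would lower the number further remains open. So does whether ethyl would have the same effect on the ester of compound 1.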